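The compounds below may be only part of what the source reports. "The series", "measured", "known", "first", "only" and "open" are said of these compounds alone.

Of the compounds shown here, three have so far been measured in a functional assay on HeLa cells (Homo sapiens) for cytotoxicity, read by MTT assay, with a stated time of 72 h; a lower number here means a stronger inhibitor, a higher number a weaker inhibitor. Compound 1 `CC(=O)N(/N=N/c1ccc([N+](=O)[O-])cc1)c1ccc([N+](=O)[O-])cc1` gives 63000 nM, compound 2 `O=C(c1ccccc1F)N(/N=N/c1ccc([N+](=O)[O-])cc1Cl)c1ccc([N+](=O)[O-])cc1Cl` gives 2350 nM, and compound 3 `O=C(c1ccccc1)N(/N=N/c1ccc([N+](=O)[O-])cc1C(F)(F)F)c1ccc([N+](=O)[O-])cc1C(F)(F)F` gives 600 nM, the lowest number of the three and the strongest inhibitor, with both gaps to the other compounds lying beyond the usual scatter.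

Compound 4 `O=C(CCl)N(/N=N/c1ccc([N+](=O)[O-])cc1C(F)(F)F)c1ccc([N+](=O)[O-])cc1C(F)(F)F` differs from compound 3 by one change: chloromethyl in place of phenyl on a carbonyl carbon. Going by the values given here, no measured pair shows this exact change on its own, so the size of the step is uncertain. With the smaller acyl group, compound 4 is expected to give a somewhat higher number than compound 3, a step of a 3.3-fold higher number from compound 3 to compound 4 (0.52 log units; beyond the scatter) that is likely to exceed the scatter. For compound 4 in this assay the estimate is 2000 nM, within a range from 500 nM to 8000 nM.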

Compound 4, half-maximal inhibitory concentration: 800 nM
The estimate for compound 4 lay 2.5-fold (0.40 log units) above the measured number, and the stated range covers the measured number.
By their numbers in this assay, from the lowest: compounds 3 and 4 (each within the scatter of the next); then compound 2; then compound 1.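

On the carbonyl carbon, chloromethyl in place of phenyl gives a 1.3-fold higher number from compound 3 to compound 4 (0.12 log units; within the scatter) in this assay, so this first single-change pair shows that the two groups cannot be told apart here. In this pair, then, the aromatic ring of the benzoyl group is not needed to keep the number at this level. Nothing measured here explains the result.

Still open, on these data alone, is whether an amine, a carboxylic acid or a longer chain at this carbonyl carbon would also stay within the scatter. Whether the same swap behaves alike on other aryl groups is also unanswered.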